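The source may report more compounds than this note shows. Statements on the series, on what has been measured and on what is new or still open speak of the compounds shown alone.

Measured compounds and their values:

Compound 1, `C[C@H](NC(=O)CN(c1nc(Cl)nc2[nH]cnc12)C1CC1)C(=O)OCc1ccccc1`, gives 23% in a functional assay on the whole organism (Tail, strain ICR) with Mus musculus as the target, in the tail flick test, with a stated time of 150 min, at a dose of 25 umol/kg by the oral route; on this read-out higher numbers stand for a stronger effect at the one dose given and lower numbers for a weaker effect.
Compound 2, `O=C(CN(c1nc(Cl)nc2[nH]cnc12)C1CC1)N[C@@H](CCC(=O)OCc1ccccc1)C(=O)OCc1ccccc1`, gives 44.5% in this assay.
Compound 3, `O=C(CN(c1ncnc2c1ncn2C1CCCCO1)C1CC1)N[C@@H](CO)C(=O)OCc1ccccc1`, gives 18.3% in this assay.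

Compound 3 carries the lowest of the three numbers; its gap to compound 1 lies within the scatter, while compound 2 stands beyond the scatter above it. Compound 4, `CC(C)C[C@H](NC(=O)CN(c1ncnc2c1ncn2C1CCCCO1)C1CC1)C(=O)OCc1ccccc1`, keeps the core of compound 3 and differs only in the side chain: isopropyl in place of hydroxy on a saturated chain carbon, two bonds along the chain from an amide-type nitrogen and a carbonyl carbon.

Among the compounds with values here, one measured step touches this place. Going a number 21.5 percentage points higher from compound 1 to compound 2 (beyond the scatter) also puts a new group on the same chain carbon in place of a hydrogen, on a core that differs from that of compound 3 and compound 4. Within the data shown here, that step rose beyond the scatter, so a rise in this assay from compound 3 to compound 4 is the expectation, though with only one guiding step it is held loosely. The expected step is a number 11.7 percentage points higher from compound 3 to compound 4 (beyond the scatter). Compound 4 is estimated at 30%, within a range from 15% to 48%.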

Compound 4, a percentage reported as activity, at one dose (the size of the read-out at that dose, not a potency): 6.47%
Compound 4: middle estimate off by 23.5 percentage points, on the high side, outside the stated range (below it).
By their numbers in this assay, from the lowest: compound 4; then compounds 3 and 1 (each within the scatter of the next); then compound 2.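

Replacing hydroxy with isopropyl on this saturated chain carbon gives a number 11.8 percentage points lower from compound 3 to compound 4 (beyond the scatter) in this assay. The earlier change at this carbon, a number 21.5 percentage points higher from compound 1 to compound 2 (beyond the scatter), went the other way, so adding carbon-containing groups here does not raise the number in every case, although the two steps differ in both the group and the core. Nothing measured here explains the fall.

Open, as far as these compounds go, is whether (benzyloxycarbonyl)methyl would lift the number on the core of compound 3 as it did on the core of compound 1. Also open, from the compounds shown here alone, is how an amine or a carboxylic acid at the end of a longer chain on this carbon would compare with hydroxy and isopropyl on the core of compound 3.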